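Cytotoxicity notes: a second methoxy on compound 2

The source may report more compounds than this note shows. Statements on the series, on what has been measured and on what is new or still open speak of the compounds shown alone.

Of the compounds shown here, three have been measured for cytotoxicity. In an ADME assay on MT4 cells (Homo sapiens) for cytotoxicity, read by MTT assay, with a stated time of 4 days (on this read-out higher numbers stand for lower toxicity in this test and lower numbers for higher toxicity in this test), compound 1 `CC(=O)Nc1ccc2oc(-c3ccccc3)cc(=O)c2c1` gives 184000 nM. Compound 2 `COc1ccccc1-c1cc(=O)c2cc(NC(C)=O)ccc2o1` gives 226000 nM in this assay, and compound 3 `COc1ccccc1-c1cc(=O)c2cc(N)ccc2o1` gives 198000 nM. Compound 2 holds the highest of the three numbers, but both its neighbours sit within the scatter: the step of a 1.2-fold higher number from compound 1 to compound 2 (0.09 log units; within the scatter) and the step of a 1.1-fold lower number from compound 2 to compound 3 (0.06 log units; within the scatter) are each too small to count as a change, so the three compounds are read as indistinguishable in this assay.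

Compound 4 `COc1ccccc1-c1oc2ccc(NC(C)=O)cc2c(=O)c1OC` differs from compound 2 by methoxy in place of hydrogen on an aromatic carbon. Among the measured compounds shown here, the one measured step that bears on this change is the addition of a methoxy on an aromatic carbon going from compound 1 to compound 2, which gave a 1.2-fold higher number from compound 1 to compound 2 (0.09 log units; within the scatter). Removing the acetyl from the nitrogen, a 1.1-fold lower number from compound 2 to compound 3 (0.06 log units; within the scatter), likewise moved nothing beyond the scatter. For the measured compounds named here, the series so far therefore offers no change of this kind that shifted the read-out, and no step beyond the scatter is expected in this assay from compound 2 to compound 4, in either direction.

Compound 4 is accordingly expected to give about 225000 nM in this assay, with a range of 120000 nM to 420000 nM. The step this estimate implies, a 1.0-fold lower number from compound 2 to compound 4 (0.00 log units; within the scatter), is expected to stay within the scatter.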

Compound 4, half-maximal cytotoxic concentration: 154000 nM
Beside the measured number, compound 4's estimate is 1.5-fold (0.16 log units) above it, within the range that was stated.
By their numbers in this assay, from the lowest: compounds 4, 1, 3 and 2 (each within the scatter of the next).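

In this assay, methoxy in place of hydrogen on this aromatic carbon of the six-membered ring with the oxygen, ortho to the 2-methoxyphenyl group and two atoms from the ring oxygen, gives a 1.5-fold lower number from compound 2 to compound 4 (0.17 log units; within the scatter), so a substituent at this position leaves the read-out within the scatter. Among the compounds shown here, the earlier steps changed only the 2-methoxyphenyl group and the acetyl on the nitrogen, so this is the first evidence from the ring that carries the oxygen, and here too no step goes beyond the scatter. No measurement at hand bears on this step, and nothing can be said of what lies behind it.

Going by these compounds, whether another group at this position, such as an amine, a carboxylic acid or a longer alkoxy chain, would move the number beyond the scatter remains open. Also open, on these data alone, is whether the same methoxy would stay within the scatter on compound 3, where the nitrogen carries no acetyl, since the change is seen here only with the acetyl in place.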